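A Triazole Replaces a Thiadiazole on a Shared Core

The source may hold more compounds than are shown below. What is called first, only, known or untested is meant among the compounds shown, and "the series" means these compounds.

Three compounds share one core and differ only in the ring attached to it. Compound 1 `CCC(C)(C)Cc1c[nH]c(CCc2ccc(-n3cccn3)cc2)n1` gives 113 nM in a functional assay on HEK293 cells for agonist activity at Bombesin receptor subtype-3 (Mus musculus), read by luminescence and calcium flux, with a stated time of 10 min; on this read-out lower numbers stand for an effect already at smaller amounts and higher numbers for an effect only at larger amounts of compound. Compound 2 `CCC(C)(C)Cc1c[nH]c(CCc2ccc(-c3cccc(N)n3)cc2)n1` gives 119 nM in this assay, and compound 3 `CCC(C)(C)Cc1c[nH]c(CCc2ccc(-c3csnn3)cc2)n1` gives 109 nM in this assay. Compound 3 has the lowest of the three numbers, yet its steps to the other two, a 1.0-fold lower number from compound 1 to compound 3 (0.02 log units; within the scatter) and a 1.1-fold lower number from compound 2 to compound 3 (0.04 log units; within the scatter), are within the scatter, so none of the three can be set apart from another.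

Compound 4 `CCC(C)(C)Cc1c[nH]c(CCc2ccc(-n3cncn3)cc2)n1` has not yet been measured. Its difference from compound 3 is 1H-1,2,4-triazol-1-yl in place of 1,2,3-thiadiazol-4-yl on an aromatic carbon. Going by the values given here, the steps that bear on this are a 1.1-fold higher number from compound 1 to compound 2 (0.02 log units; within the scatter), a 1.0-fold lower number from compound 1 to compound 3 (0.02 log units; within the scatter) and a 1.1-fold lower number from compound 2 to compound 3 (0.04 log units; within the scatter): each exchange of the ring at this position left the number where it was. Because a 1.1-fold lower number from compound 2 to compound 3 (0.04 log units; within the scatter) and a 1.0-fold lower number from compound 1 to compound 3 (0.02 log units; within the scatter) were both within the scatter, the expected change is a 1.1-fold higher number from compound 3 to compound 4 (0.02 log units; within the scatter), no larger than the scatter and in no particular direction. Compound 4 is therefore estimated at 115 nM, with a range from 60 nM to 220 nM in this assay.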

Compound 4, half-maximal effective concentration: 121 nM
The estimate for compound 4 lay 1.1-fold (0.02 log units) below the measured number; low and high end bracket the measured number.
By their numbers in this assay, from the lowest: compounds 3, 1, 2 and 4 (each within the scatter of the next).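

Putting the 1H-1,2,4-triazol-1-yl in place of the 1,2,3-thiadiazol-4-yl, a ring of the same size with no sulfur, gives a 1.1-fold higher number from compound 3 to compound 4 (0.05 log units; within the scatter) in this assay and shows that sulfur in this ring is not required for a number in this range. The other two comparisons agree, with a 1.1-fold higher number from compound 1 to compound 4 (0.03 log units; within the scatter) and a 1.0-fold higher number from compound 2 to compound 4 (0.01 log units; within the scatter) both inside the usual scatter. All four rings at this place, on an aromatic carbon para to a large group, now give numbers that cannot be told apart, so this position accepts each of these rings equally well.

As far as these compounds go, it remains open whether a carboxylic acid or a plain methyl group at this place, rather than an aromatic ring, would give a different number. Nothing available explains why these four rings give such closely matched numbers.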